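The source may report more compounds than this note shows. Statements on the series, on what has been measured and on what is new or still open speak of the compounds shown alone.

Values in a functional assay on RT-112 cells (Homo sapiens) for antiproliferative activity, read by MTT assay, with a stated time of 72 h; on this read-out higher numbers stand for weaker inhibition of growth and lower numbers for stronger inhibition of growth:
- compound 1 `COc1cc(Nc2ncnc3c(NC(=O)Nc4ccc(C)c(C)c4)cccc23)cc(OC)c1`: 8.8 nM
- compound 2 `COc1cc(Nc2ncnc3c(NC(=O)Nc4cc(C)cc(C)c4)cccc23)cc(OC)c1`: 10100 nM

Compound 2, at 10100 nM, holds the higher of the two numbers in this assay. Compound 3 `COc1cc(Nc2ncnc3c(NC(=O)Nc4ccc(Cl)cc4)cccc23)cc(OC)c1` carries 4-chlorophenyl in place of 3,5-dimethylphenyl on an amide-type nitrogen. Within the data shown here, the one measured step bearing on this is a 1100-fold higher number from compound 1 to compound 2 (3.06 log units; beyond the scatter), which is large and beyond the scatter, and it shows how strongly this group can move the number. Among the measured compounds shown here, no measured compound carries 4-chlorophenyl, so the estimate is loose. A large step to a lower number is expected in this assay, with 3,5-dimethylphenyl gone. The expected step is a 67-fold lower number from compound 2 to compound 3 (1.83 log units; beyond the scatter). For compound 3 the estimated value is 150 nM, with an expected range of 15 nM to 3000 nM.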

Compound 3, concentration for 50% growth inhibition: 2490 nM
Estimate against measurement, compound 3: 17-fold (1.22 log units) below; the range from low to high includes it.
By their numbers in this assay, from the lowest: compound 1; then compound 3; then compound 2.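

In this assay, 4-chlorophenyl in place of 3,5-dimethylphenyl gives a 4.1-fold lower number from compound 2 to compound 3 (0.61 log units; beyond the scatter), while 4-chlorophenyl in place of 3,4-dimethylphenyl gives a 280-fold higher number from compound 1 to compound 3 (2.45 log units; beyond the scatter). The low number at this amide-type nitrogen therefore belongs to compound 1 alone among the three groups shown, and the change to 4-chlorophenyl recovers only a small part of the gap. No data on hand account for this order. Open, from the compounds shown here alone, is whether 3,4-dichlorophenyl would track compound 1 or compound 3. Unsubstituted phenyl and 4-methylphenyl would show how much each methyl of 3,4-dimethylphenyl contributes.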